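Bromo for allyloxy on the aromatic carbon of compound 2

The source may report more compounds than this note shows. Statements on the series, on what has been measured and on what is new or still open speak of the compounds shown alone.

Three measured analogues share one core and differ only at one aromatic carbon. In an assay for inhibition of Dihydrofolate reductase (Gallus gallus) (on this read-out lower numbers stand for stronger inhibition and higher numbers for weaker inhibition), compound 1 `Cc1ccccc1Cc1cnc(N)nc1N` gives 29500 nM, compound 2 `C=CCOc1ccccc1Cc1cnc(N)nc1N` gives 21400 nM, and compound 3 `CS(=O)(=O)Oc1ccccc1Cc1cnc(N)nc1N` gives 22900 nM. Compound 2 sits within the scatter of both others: a 1.4-fold lower number from compound 1 to compound 2 (0.14 log units; within the scatter) and a 1.1-fold higher number from compound 2 to compound 3 (0.03 log units; within the scatter). Compound 4 `Nc1ncc(Cc2ccccc2Br)c(N)n1` carries the change (bromo in place of allyloxy on an aromatic carbon). The two steps that touch this same position are the ones just given, and neither leaves the scatter, so no step beyond the scatter in either direction is expected from this change in this assay. Compound 4 is therefore estimated at 25000 nM, with a range from 10000 nM to 60000 nM, which corresponds to an expected step of a 1.2-fold higher number from compound 2 to compound 4 (0.07 log units; within the scatter).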

Compound 4, inhibition constant: 12300 nM
Estimate against measurement, compound 4: 2.0-fold (0.31 log units) above; the measured number falls inside the stated range.
By their numbers in this assay, from the lowest: compounds 4, 2, 3 and 1 (each within the scatter of the next, the first and the last beyond it).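

Within the data shown here, at this aromatic carbon, bromo gives the only step beyond the scatter so far in this assay, and that step is modest and taken from methyl (a 2.4-fold lower number from compound 1 to compound 4 (0.38 log units; beyond the scatter)). Against the two oxygen-linked groups, bromo stays within the scatter (a 1.7-fold lower number from compound 2 to compound 4 (0.24 log units; within the scatter)) (and a 1.9-fold lower number from compound 3 to compound 4 (0.27 log units; within the scatter)), so a single bromine atom matches allyloxy and (methylsulfonyl)oxy on this read-out. No measured information accounts for this result. Still open, going by these compounds, is whether chloro or iodo at this carbon would read like bromo. An amine or a carboxylic acid there also remains untested within the compounds shown.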